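The source may report more compounds than this note shows. Statements on the series, on what has been measured and on what is new or still open speak of the compounds shown alone.

Of the compounds shown here, three sharing one core have been measured in an assay on isolated protein for inhibition of protein kinase C zeta type (Homo sapiens), with stated times of 1 h and 2.5 min, tested at 30 uM; on this read-out higher numbers stand for more inhibition at the one concentration tested (going by the name of the read-out) and lower numbers for less inhibition. Compound 1 `COCCOC(=O)c1c(-c2ccc(OC)c(OC)c2)csc1N` gives 57% in this assay. Compound 2 `COc1ccc(-c2csc(N)c2C(=O)OCc2ccccc2C)cc1OC` gives 64%, the highest of the three numbers, though the step of a number 7 percentage points higher from compound 1 to compound 2 (within the scatter) is within the scatter. Compound 3 `COc1ccc(-c2csc(N)c2C(=O)NCc2ccncc2)cc1OC` gives 3%; the drop a number 54 percentage points lower from compound 1 to compound 3 (beyond the scatter) and the drop a number 61 percentage points lower from compound 2 to compound 3 (beyond the scatter) are both large.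

Compound 4 `COc1ccc(-c2csc(N)c2C(=O)O)cc1OC` is not yet measured. It differs from compound 2 by hydrogen in place of 2-methylbenzyl on an oxygen next to a carbonyl group.

For the measured compounds named here, two measured steps bear on this. Exchanging one ester group for another gave a number 7 percentage points higher from compound 1 to compound 2 (within the scatter), so the identity of the group on that oxygen mattered little. Replacing the whole ester substituent by an amine-bearing group gave a number 61 percentage points lower from compound 2 to compound 3 (beyond the scatter), a large loss. Removing the benzyl group entirely is closer to the second kind of change than the first, so a loss beyond the scatter is expected, of size a number 39 percentage points lower from compound 2 to compound 4 (beyond the scatter). Compound 4 is therefore estimated at 25%, within 0% to 55%.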

Compound 4, a percentage reported as inhibition, at one concentration (the size of the read-out at that concentration, not a potency): 65%
For compound 4 the middle estimate is 40 percentage points below the measured one; measured number above the stated range.
By their numbers in this assay, from the lowest: compound 3; then compounds 1, 2 and 4 (each within the scatter of the next).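

In this assay removing the whole 2-methylbenzyl group from the oxygen next to a carbonyl group gives a number 1 percentage points higher from compound 2 to compound 4 (within the scatter) and removing 2-methoxyethyl gives a number 8 percentage points higher from compound 1 to compound 4 (within the scatter) so this read-out does not depend on an ester group at this place. For the compounds shown here, the earlier compounds showed only that one ester group could replace another, whereas these steps show that hydrogen on this oxygen also reads like both esters. Among the four compounds, only ((pyridin-4-yl)methyl)amino on the carbonyl carbon stands apart, with a number 62 percentage points higher from compound 3 to compound 4 (beyond the scatter) on going to hydroxy.

A plain primary amide or a benzyl amide on the same carbonyl carbon would help show whether the low number goes with the amide link or with the pyridine ring. Nothing available here gives a reason for these numbers.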